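From Acetyl to Chloro: Compound 1 to Compound 4

This account rests on a few compounds, and the source may have more. Where it says the series, first, only, none or still open, it means among the compounds named here.

Of the compounds shown here, three sharing one core have been tested in a functional assay on Molt4/C8 cells (Homo sapiens) for cytotoxicity; on this read-out higher numbers stand for weaker inhibition and lower numbers for stronger inhibition. Compound 1 `CC(=O)c1ccc(NC(=O)/C=C/C(=O)N2C/C(=C\c3ccccc3)C(=O)/C(=C/c3ccccc3)C2)cc1` gives 1400 nM, the highest of the three numbers. Compound 3 `O=C(/C=C/C(=O)N1C/C(=C\c2ccc([N+](=O)[O-])cc2)C(=O)/C(=C/c2ccc([N+](=O)[O-])cc2)C1)Nc1ccc(Cl)cc1` gives 1200 nM and compound 2 `COc1ccc(NC(=O)/C=C/C(=O)N2C/C(=C\c3ccc([N+](=O)[O-])cc3)C(=O)/C(=C/c3ccc([N+](=O)[O-])cc3)C2)cc1` gives 940 nM; both lie within the scatter of compound 1, so no order can be claimed among them. Within the data shown here, the only single-point step measured is a 1.3-fold higher number from compound 2 to compound 3 (0.11 log units; within the scatter).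

Compound 4 `O=C(/C=C/C(=O)N1C/C(=C\c2ccccc2)C(=O)/C(=C/c2ccccc2)C1)Nc1ccc(Cl)cc1` differs from compound 1 as follows: chloro in place of acetyl on an aromatic carbon. Among the measured compounds shown here, no measured pair changes acetyl to chloro on that ring. The nearest guide is the step from methoxy to chloro on the same ring, a 1.3-fold higher number from compound 2 to compound 3 (0.11 log units; within the scatter), which stayed within the scatter. Compound 4 is therefore expected to show no step beyond the scatter, a 1.1-fold lower number from compound 1 to compound 4 (0.03 log units; within the scatter). Compound 4 is estimated at 1300 nM, between 600 nM and 3000 nM.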

Compound 4, half-maximal inhibitory concentration: 1800 nM
For compound 4 the middle estimate is 1.4-fold (0.14 log units) below the measured one, and the stated range covers the measured number.
By their numbers in this assay, from the lowest: compounds 2, 3, 1 and 4 (each within the scatter of the next).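

In this assay, chloro in place of acetyl gives a 1.3-fold higher number from compound 1 to compound 4 (0.11 log units; within the scatter). On this aromatic carbon, para to a large group, a single chlorine atom can thus replace the three heavy atoms of acetyl and its hydrogen-bond acceptor without a step beyond the scatter, and this now holds in compounds without the nitro groups of compound 2 and compound 3. No supporting evidence bears on this result.

Going by these compounds, whether an amine or a carboxylic acid on this carbon would produce a step beyond the scatter remains open.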